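This account rests on a few compounds, and the source may have more. Where it says the series, first, only, none or still open, it means among the compounds named here.

Compounds measured so far:
compound 1 `CCn1c(-c2ccccc2)nc2c(NC3CCCCC3)ncnc21` — 9020 nM
compound 2 `CCCn1c(-c2ccccc2)nc2c(NC3CCCC3)ncnc21` — 3430 nM
compound 3 `CCCn1c(-c2ccccc2)nc2c(NC3CCOC3)ncnc21` — 9080 nM

All three values come from a functional assay on CHO cells for antagonist activity at adenosine receptor A2b (Homo sapiens), read by 33P incorporation, with a stated time of 20 min; a lower number here means a stronger inhibitor, a higher number a weaker inhibitor. Compound 3 stands highest of the three numbers, but its gap to compound 1 is within the scatter; only compound 2 lies clearly apart, with a 2.6-fold higher number from compound 2 to compound 3 (0.42 log units; beyond the scatter) marking the move from cyclopentyl to oxolan-3-yl on the nitrogen on the aromatic ring.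

Compound 4 `CCCn1c(-c2ccccc2)nc2c(NC3CCCCC3)ncnc21` is not yet measured in this assay. It differs from compound 3 by cyclohexyl in place of oxolan-3-yl on a nitrogen on an aromatic ring. For the measured compounds named here, one measured step bears on this directly: the step from cyclopentyl to oxolan-3-yl, a 2.6-fold higher number from compound 2 to compound 3 (0.42 log units; beyond the scatter), which ran toward a weaker inhibitor. Going back from oxolan-3-yl to a carbocycle might be expected to reverse that, though the ring entering is six-membered rather than five-membered. Compound 1, which carries the same cyclohexyl group with ethyl rather than propyl on the other ring nitrogen, gives 9020 nM, which is no stronger than compound 3. Going by the values given here, no step is given between compound 1 and compound 4, so only their two values can be compared once the latter is known.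

Weighing these, a modest move toward a lower number is expected, a 2.0-fold lower number from compound 3 to compound 4 (0.30 log units; within the scatter), with compound 4 estimated at 4500 nM (range 1800 nM to 11000 nM).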

Compound 4, inhibition constant: 5310 nM
Compound 4: the middle estimate sits 1.2-fold (0.07 log units) below what was measured; measured number inside the range.
By their numbers in this assay, from the lowest: compounds 2, 4, 1 and 3 (each within the scatter of the next, the first and the last beyond it).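

In this assay, cyclohexyl in place of oxolan-3-yl on the nitrogen on the aromatic ring gives a 1.7-fold lower number from compound 3 to compound 4 (0.23 log units; within the scatter), so this change does not clearly undo the earlier step of a 2.6-fold higher number from compound 2 to compound 3 (0.42 log units; beyond the scatter), even though the oxygen-containing ring leaves and an all-carbon ring enters. Ring size among the carbocycles is not resolved at this position either: cyclohexyl in place of cyclopentyl gives a 1.5-fold higher number from compound 2 to compound 4 (0.19 log units; within the scatter), and compound 4 thus lies within the scatter of both compound 2 and compound 3, although those two lie beyond the scatter of each other. For the compounds shown here, the first reading on the other chain, methyl in place of hydrogen on a saturated chain carbon, two bonds along the chain from an aromatic nitrogen, gives a 1.7-fold lower number from compound 1 to compound 4 (0.23 log units; within the scatter), so propyl and ethyl are not separated when cyclohexyl is present.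

The compounds shown leave open whether an amine in the ring, as in piperidin-4-yl, or a longer chain such as butyl in place of propyl would shift the number beyond the scatter of these values. No evidence is available that bears on what lies behind these steps.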